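Swapping a pyrrolidine for a piperidine on the side chain

A few compounds are considered here, and "the series" means these few. Any claim that something is new, unique, unknown or untested is made for them only; others in the source may bear on it.

Three close relatives built on the same core are in view. Compound 1, `COc1cc2c(Oc3ccc(NC(=O)c4cc(-c5ccccc5F)ccn4)cc3F)ccnc2cc1OCCCN1CCCCC1`, has no reported result: in a functional assay on U-87MG ATCC cells (Homo sapiens) for cytotoxicity, read by MTT assay, with a stated time of 72 h (a higher number here means a weaker inhibitor, a lower number a stronger inhibitor), compound 1 stands at "not determined" (no result reported), and its entry is otherwise empty. Among the measured compounds shown here, compound 2, `COc1cc2c(Oc3ccc(NC(=O)c4cc(-c5ccccc5)ccn4)cc3F)ccnc2cc1OCCCN1CCCC1`, is therefore the only member with a number: in this assay compound 2 gives 1010 nM, and with no second measured compound to set beside it, nothing can yet be said about how it ranks against its neighbours.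

Compound 3, `COc1cc2c(Oc3ccc(NC(=O)c4cc(-c5ccccc5)ccn4)cc3F)ccnc2cc1OCCCN1CCCCC1`, differs from compound 2 in a single spot on the side chain: piperidin-1-yl in place of pyrrolidin-1-yl on a saturated chain carbon, three bonds along the chain from an oxygen on an aromatic ring. The amide, the fluorinated phenyl ether and the rest of the core are untouched. Nothing measured here tells how such a swap moves the read-out, so the honest expectation is a step no larger than the ordinary scatter, in either direction. On that basis the estimated step of a 1.0-fold lower number from compound 2 to compound 3 (0.00 log units; within the scatter) is small, and compound 3 is expected to give about 1000 nM in this assay, with a likely range from 400 nM to 2500 nM.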

Compound 3, half-maximal inhibitory concentration: 790 nM
The estimate for compound 3 lay 1.3-fold (0.10 log units) above the measured number, within the range that was stated.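

Placing the six-membered piperidin-1-yl ring where the five-membered pyrrolidin-1-yl ring stood gives, in this assay, a 1.3-fold lower number from compound 2 to compound 3 (0.11 log units; within the scatter), so the two compounds cannot be told apart in this test. Among the compounds shown here, this is the first direct comparison at this position, on a saturated chain carbon, three bonds along the chain from an oxygen on an aromatic ring, and it shows that this particular ring swap moves the number no further than repeat measurements ordinarily would. Nothing measured alongside these compounds speaks to why the two rings behave alike here.

Still open, from the compounds shown here alone, is whether the end of the side chain accepts a more different group, such as a morpholine, a dimethylamino group or a carboxylic acid, or a longer chain than 3-(piperidin-1-yl)propyl, any of which would show how far the read-out can move from this position. For the compounds shown here, the effect of the extra fluorine on the phenyl group of compound 1 also cannot be read from these values, so a single pair with one small step is all that can be said about this series so far.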